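Styryl sulfonamides: amino acid substituent variation on the aniline ring

This account rests on a few compounds, and the source may have more. Where it says the series, first, only, none or still open, it means among the compounds named here.

Measured compounds:
compound 1 `COc1ccc(NS(=O)(=O)/C=C/c2c(OC)cc(OC)cc2OC)cc1`, 200 nM
compound 2 `COC(=O)C(Nc1cc(NS(=O)(=O)/C=C/c2c(OC)cc(OC)cc2OC)ccc1OC)c1ccccc1`, 2500 nM

In a functional assay on DU-145 cells (Homo sapiens) for cytotoxicity, read by trypan blue exclusion, with a stated time of 96 h (on this read-out lower numbers stand for stronger inhibition and higher numbers for weaker inhibition), compound 1 gives 200 nM. Among the measured compounds shown here, compound 2 stands at the highest of the two numbers, and the one step known, a 13-fold higher number from compound 1 to compound 2 (1.10 log units; beyond the scatter), is the only measured change.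

Compound 3 `COc1cc(OC)c(/C=C/S(=O)(=O)Nc2ccc(OC)c(NC(C(=O)O)c3ccc(F)cc3)c2)c(OC)c1` differs from compound 2 by carboxy(4-fluorophenyl)methyl in place of methoxycarbonyl)(benzyl on a nitrogen on an aromatic ring. For the measured compounds named here, no measured step addresses this exchange; the step from compound 1 to compound 2 concerns the introduction of the whole group and not a change within it, so it gives only indirect guidance. Going by the values given here, with no comparable pair, the expectation is that the substituted compounds stay in the same region, and a step of a 1.2-fold higher number from compound 2 to compound 3 (0.08 log units; within the scatter) is estimated, close to none beyond the scatter. Compound 3 is therefore expected at about 3000 nM, with a range from 1000 nM to 10000 nM.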

Compound 3, half-maximal inhibitory concentration: 75 nM
Estimate against measurement, compound 3: 40-fold (1.60 log units) above, and the stated range ends above it.
By their numbers in this assay, from the lowest: compound 3; then compound 1; then compound 2.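

In this assay substitution on this nitrogen on an aromatic ring carries no fixed penalty: the exchange gives a 33-fold lower number from compound 2 to compound 3 (1.52 log units; beyond the scatter) even though the leaving and entering groups have the same heavy-atom count, so group size alone does not set the number here. Set against the core of compound 1, the entering group gives a 2.7-fold lower number from compound 1 to compound 3 (0.43 log units; beyond the scatter) and so moves the number below that of the unsubstituted compound, whereas the group in compound 2 moved it above. No measurement shown explains this change.

The exchange alters the carboxy or methoxycarbonyl end and the fluorine on the phenyl ring together, so their separate shares stay unresolved. Also open, going by these compounds, is how a primary amide in place of the carboxy group, or chlorine in place of the fluorine, would read.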